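A few compounds are considered here, and "the series" means these few. Any claim that something is new, unique, unknown or untested is made for them only; others in the source may bear on it.

Measured compounds:
- compound 1, `CO[C@@H]1CC=C2NN(c3cc4ccccc4[nH]3)C(=O)C[C@]2(C)O1`: 18300 nM
- compound 2, `CO[C@@H]1CC=C2NN(c3cc4ccccc4[nH]3)C(=O)C[C@]2(c2ccccc2)O1`: 8200 nM
- compound 3, `CO[C@@H]1CC=C2NN(c3cncnc3)C(=O)C[C@]2(C)O1`: 15100 nM

All three were tested in a functional assay on HCT-116 cells (Homo sapiens) for inhibition, read by sulforhodamine B assay, with a stated time of 48 h; on this read-out higher numbers stand for weaker inhibition and lower numbers for stronger inhibition. Compound 1 and compound 2 share one core and differ in a single place: phenyl in place of methyl on a saturated ring carbon. That change brought a 2.2-fold lower number from compound 1 to compound 2 (0.35 log units; beyond the scatter). Compound 3 carries a different core; the difference between the two cores is not broken down here. In this assay compound 3 gives 15100 nM, and compound 1 gives 18300 nM, two values that sit close together.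

Compound 4, `CO[C@@H]1CC=C2NN(c3cncnc3)C(=O)C[C@]2(c2ccccc2)O1`, has not yet been measured. It stands to compound 3 as compound 2 stands to compound 1: phenyl in place of methyl on a saturated ring carbon. The place is described in the same words for both pairs, so this is the same change made a second time, on the other core. Among the compounds shown it occurs twice in all, and only the first of the two is measured.

The expectation for compound 4 rests on that single earlier step, because a 2.2-fold lower number from compound 1 to compound 2 (0.35 log units; beyond the scatter) is the only measured record of what this change does. If the second core responds in the same way, the expected step would be a 2.2-fold lower number from compound 3 to compound 4 (0.33 log units; beyond the scatter), of about the same size as the step from compound 1 to compound 2. Starting from compound 3, compound 4 is therefore expected to give roughly 7000 nM in this assay, with a plausible range from 3500 nM to 14000 nM.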

Compound 4, half-maximal inhibitory concentration: 9130 nM
Estimate against measurement, compound 4: 1.3-fold (0.12 log units) below, within the range that was stated.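

In this assay the swap of methyl for phenyl on the second core gave a 1.7-fold lower number from compound 3 to compound 4 (0.22 log units; within the scatter), and the lines below set it beside the first case, where the two steps do not differ: the same change on two cores in this assay, a 2.2-fold lower number (0.35 log units; beyond the scatter) from compound 1 to compound 2 and a 1.7-fold lower number (0.22 log units; within the scatter) from compound 3 to compound 4, 1.3-fold (0.13 log units) apart, within the scatter of two such steps. Going by these compounds alone, this shows that the change behaved alike on these two cores, with both steps pointing the same way and no measurable gap between them, but it rests on only two pairs and says nothing about any other core, and the second step taken alone lies within the scatter, so it does not establish a real gain on that core. The swap of the group on the amide-type nitrogen in a ring, pyrimidin-5-yl in place of 1H-indol-2-yl with phenyl kept on the saturated ring carbon, gave a 1.1-fold higher number from compound 2 to compound 4 (0.05 log units; within the scatter), which is also within the scatter, so this pair does not separate the two groups.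

The compounds shown hold only methyl and phenyl on that saturated ring carbon, which leaves open how a longer chain, a benzyl group or an amine there would fare, and whether its step would again match across both cores. They also leave open what a carboxylic acid or a plain phenyl on the amide-type nitrogen would do.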